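The source may report more compounds than this note shows. Statements on the series, on what has been measured and on what is new or still open speak of the compounds shown alone.

Of the compounds shown here, three with a shared core have been tested so far in a functional assay on NCI-H460 cells (Homo sapiens) for inhibition, read by CCK-8 assay, with a stated time of 72 h, tested at 1 uM (a lower number here means less inhibition of growth, a higher number more inhibition of growth at the concentration tested), and their numbers are far apart. Compound 1 `CN(C)C(=O)c1cc2cnc(Nc3ccc(N)cn3)nc2n1C1CCCC1` gives -0.6% in this test, compound 2 `CN(C)C(=O)c1cc2cnc(Nc3ccc(NC(=O)C4(C(=O)Nc5ccc(Cl)cc5)CC4)cc3)nc2n1C1CCCC1` gives 21.3% and compound 3 `CN(C)C(=O)c1cc2cnc(Nc3ccc(NC(=O)C4(C(=O)Nc5cccc(F)c5)CC4)cc3)nc2n1C1CCCC1` gives 45.1%, the highest of the three.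

Compound 4 `CN(C)C(=O)c1cc2cnc(Nc3ccc(NC(=O)C4(C(=O)Nc5ccc(Br)cc5)CC4)cc3)nc2n1C1CCCC1` has not been measured yet. It differs from compound 3 by a single exchange: 4-bromophenyl in place of 3-fluorophenyl on an amide-type nitrogen, with 4-bromophenyl in place of 3-fluorophenyl on an amide-type nitrogen.

Among the compounds with values here, only one measured step bears on this exchange. Putting 3-fluorophenyl in place of 4-chlorophenyl on that nitrogen gave a number 23.8 percentage points higher from compound 2 to compound 3 (beyond the scatter) and the new exchange runs roughly the opposite way. By name, 4-bromophenyl stands closer to 4-chlorophenyl than to 3-fluorophenyl, although no measurement here compares the two directly. One step is thin evidence, so the expectation is loose: a fall from compound 3 towards the level of compound 2 at 21.3% is the likeliest outcome. In this assay the estimated change is a number 20.1 percentage points lower from compound 3 to compound 4 (beyond the scatter), a loss of growth inhibition of about the size of that earlier step. For compound 4 the expected value is 25%, with an estimated range from 8% to 45%.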

Compound 4, percent growth inhibition at one concentration: 31.5%
Estimate against measurement, compound 4: 6.5 percentage points below, and the stated range covers the measured number.
By their numbers in this assay, from the lowest: compound 1; then compound 2; then compound 4; then compound 3.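

Exchanging 3-fluorophenyl for 4-bromophenyl on the amide-type nitrogen gives a number 13.6 percentage points lower from compound 3 to compound 4 (beyond the scatter) in this assay, so 3-fluorophenyl keeps the highest number among the groups tested there. That exchange changes both the halogen and its place on the ring, so on its own it cannot show which of the two matters. Within the data shown here, the new compound also allows the first comparison of two halogens at one place, and bromo in place of chloro on an aromatic carbon gives a number 10.2 percentage points higher from compound 2 to compound 4 (beyond the scatter), which shows that the number responds to the identity of the halogen even when its place stays the same, while nothing here gives a reason for either step.

Going by these compounds, what remains open is whether the higher number of compound 3 comes from fluorine itself or from its place on the ring, a question that 4-fluorophenyl and 3-bromophenyl on the same nitrogen would help to separate. On these data alone, it is also open how this position would respond to a group without a halogen, such as unsubstituted phenyl, 4-methoxyphenyl or a phenyl ring carrying a carboxylic acid.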